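Notes on replacing 4-(tert-butyl)benzyl with 3-chlorobenzyl

The compounds below may be only part of what the source reports. "The series", "measured", "known", "first", "only" and "open" are said of these compounds alone.

Values in a toxicity assay on NIH3T3 cells (Mus musculus) for cytotoxicity, read by resazurin assay; on this read-out lower numbers stand for an effect already at smaller amounts and higher numbers for an effect only at larger amounts of compound
compound 1 `COC(=O)c1ccc(NCc2cncn2Cc2ccc(-c3ccccc3)cc2)cc1-c1ccccc1` - > 1000 nM (a limit)
compound 2 `COC(=O)c1ccc(NCc2cncn2Cc2cccc(N)c2)cc1-c1ccccc1` - > 10000 nM (a limit)
compound 3 `COC(=O)c1ccc(NCc2cncn2Cc2ccc(C(C)(C)C)cc2)cc1-c1ccccc1` - "not determined" (no result reported)
compound 4 `COC(=O)c1ccc(NCc2cncn2Cc2cccc(Cl)c2)cc1-c1ccccc1` - not yet measured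

In this assay compound 3 stands at "not determined" (no result reported), so it offers no number to start from. The neighbouring values are limits, not numbers. Compound 1 sits at the limit of > 1000 nM in this assay, at which 1 of the 3 values shown sits. Compound 2 sits at the limit of > 10000 nM in this assay, at which 1 of the 3 values shown sits.

The step to compound 4 is 3-chlorophenyl in place of 4-(tert-butyl)phenyl on a saturated chain carbon bound to an aromatic nitrogen. Cut one bond further out, the same difference reads 4-(tert-butyl)benzyl to 3-chlorobenzyl.

For the measured compounds named here, one measured step bears on this change, as it falls at the same place on a saturated chain carbon bound to an aromatic nitrogen: a step that the two limits leave unreadable from compound 1 to compound 2. Going by the values given here, it offers no size or direction to carry over, and compound 3 has no number to step from, so no step of any particular size is expected.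

The nearest guide is compound 2, with its 3-aminophenyl, whose limit is > 10000 nM. A high value is therefore expected, and the assay may report only a limit. For compound 4 the expected value is about 10000 nM, with an estimated range from 2500 nM to 40000 nM.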

Compound 4, half-maximal effective concentration: > 10000 nM
Compound 4: only a limit was reported; the forecaster's own chance of this, stated with the estimate: 60%; the middle value sits exactly at the limit.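

In this assay compound 4 gives > 10000 nM, a limit and not a number. The steps from compound 1 and from compound 2 to compound 4 cannot be read, with limits at both ends of each. The compounds shown leave open how far 3-chlorophenyl, 3-aminophenyl and 4-phenylphenyl actually differ in this assay, and where compound 3 stands.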